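Pyridine-core glucagon series: ring swap from compound 1

The source may hold more compounds than are shown below. What is called first, only, known or untested is meant among the compounds shown, and "the series" means these compounds.

Measured so far:
- compound 1 `CCCCCc1c(C(C)C)nc(C(C)C)c(CO)c1-c1ccc(CC)cc1`: 42%
- compound 2 `CCC/C=C/c1c(C(C)C)nc(C(C)C)c(CO)c1-c1ccc(S(C)(=O)=O)cc1`: 14%
- compound 3 `CCCCCc1c(C(C)C)nc(C(C)C)c(CO)c1-c1ccc(O)cc1`: 24%

In an assay on CHO cells for inhibition of Glucagon receptor (Homo sapiens), tested at 20 uM (on this read-out lower numbers stand for less inhibition and higher numbers for more inhibition at the one concentration tested (going by the name of the read-out)), compound 1 gives the highest of the three numbers, with compound 3 nearest and compound 2 furthest; both steps lie beyond the scatter. For the measured compounds named here, the one single-point step runs a number 18 percentage points lower from compound 1 to compound 3 (beyond the scatter), a modest drop for hydroxy in place of ethyl on the aromatic carbon. Compound 2 differs from compound 1 in two places at once, so its value speaks only on its own.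

Compound 4 `CCCCCc1c(C(C)C)nc(C(C)C)c(CO)c1-c1ccccc1OC` is not yet measured. It differs from compound 1 by 2-methoxyphenyl in place of 4-ethylphenyl on an aromatic carbon. Going by the values given here, the ethyl of compound 1 leaves and a methoxy enters on the same ring, with an acceptor gained; the step from compound 1 to compound 3 is the only close guide, and it went down. A step of similar size, downward, is therefore expected: a number 16 percentage points lower from compound 1 to compound 4 (beyond the scatter). Compound 4 is estimated at 26%, between 8% and 44%.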

Compound 4, a percentage reported as inhibition, at one concentration (the size of the read-out at that concentration, not a potency): 27%
The estimate for compound 4 lay 1 percentage points below the measured number, within the range that was stated.
By their numbers in this assay, from the lowest: compounds 2, 3 and 4 (each within the scatter of the next, the first and the last beyond it); then compound 1.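

In this assay, the position opposite the ring nitrogen now shows a second replacement of 4-ethylphenyl that costs inhibition: 2-methoxyphenyl gives a number 15 percentage points lower from compound 1 to compound 4 (beyond the scatter) and so joins 4-hydroxyphenyl below compound 1. Set against 4-hydroxyphenyl, it gives a number 3 percentage points higher from compound 3 to compound 4 (within the scatter) and so the two groups cannot be told apart here, although they differ both in the substituent and in its place on the phenyl ring. No measurement on hand explains the loss or this match.

The compounds shown do not separate the effect of the methoxy group from that of its place on the ring, which a 4-methoxyphenyl or 2-ethylphenyl group would address. Going by these compounds, how a longer chain such as 4-butylphenyl or an amine such as 4-aminophenyl would compare with 4-ethylphenyl at this position also remains open.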